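The compounds below may be only part of what the source reports. "The series", "measured", "known", "first", "only" and "open" are said of these compounds alone.

Compound 1 `Cc1cc(-c2ccco2)nc(Nc2ccc(N(C)C)cc2)n1`: 5900 nM
Compound 2 `CN(C)c1ccc(Nc2nccc(-c3ccco3)n2)cc1`: 1900 nM
Compound 3 `Cc1cc(-c2ccncc2)nc(Nc2ccc(N(C)C)cc2)n1`: > 24000 nM

These three compounds share one core and were tested in a functional assay for inhibition, with Homo sapiens as the target; on this read-out higher numbers stand for weaker inhibition and lower numbers for stronger inhibition. Among the two actual numbers, compound 1 gives the higher one, and compound 2 is the nearest to it: the step of a 3.1-fold lower number from compound 1 to compound 2 (0.49 log units; beyond the scatter) comes with hydrogen in place of methyl on an aromatic carbon. For compound 3 the result is only a limit of the assay, (the limit of > 24000 nM in this assay, at which 1 of the 3 values shown sits). The step of an at least 4.0-fold higher number from compound 1 to compound 3 (0.60 log units; beyond the scatter) goes with pyridin-4-yl in place of furan-2-yl on an aromatic carbon.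

Compound 4 `Cc1cc(-c2ccco2)nc(Nc2ccccc2)n1` has not been measured yet. It differs from compound 1 by hydrogen in place of dimethylamino on an aromatic carbon. Neither measured step touches this part of the molecule: one alters the methyl, the other the furan-2-yl. Within the data shown here, no measured step therefore bears directly on this change. Both measured changes elsewhere moved the number by a modest amount or more, so a shift of similar size is plausible here too, but its direction cannot be read from these data. Compound 4 is expected to give 10000 nM, with a range from 3000 nM to 30000 nM, which means an expected step of a 1.7-fold higher number from compound 1 to compound 4 (0.23 log units; within the scatter).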

Compound 4, half-maximal inhibitory concentration: 17700 nM
The estimate for compound 4 lay 1.8-fold (0.25 log units) below the measured number; measured number inside the range.
By their numbers in this assay, from the lowest: compound 2; then compound 1; then compound 4. At a limit, above all of these: compound 3.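

In this assay, taking away the dimethylamino group and leaving hydrogen on the six-membered aromatic ring of carbon only gives a 3.0-fold higher number from compound 1 to compound 4 (0.48 log units; beyond the scatter), so within this pair the dimethylamino group goes with stronger inhibition. Among these compounds, the earlier steps changed only the methyl and the furan-2-yl, so this is the first evidence that this other part of the molecule also matters, with a step beyond the usual scatter of the assay. Nothing measured here explains why the number rises with this change.

The compounds shown compare only dimethylamino and hydrogen at this position, so it stays open whether a plain amino group, a different amine such as pyrrolidine, or an ether such as methoxy would behave like dimethylamino, like hydrogen or like neither. Going by these compounds, it also stays open whether the same swap would give a similar step on compound 2, which carries hydrogen in place of the methyl, or on compound 3, whose result is only a limit of the assay and so gives no exact starting point.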